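The compounds below may be only part of what the source reports. "The series", "measured", "known", "first", "only" and "open" are said of these compounds alone.

Working notes on the series. Compound 1 `O=C1C=COC(/C=C/c2ccccc2)C1` and compound 2 `COc1ccc(/C=C/C2CC(=O)C=CO2)cc1` share one core; compound 3 `COc1ccc(/C=C/c2cc(=O)cco2)cc1` and compound 4 `COc1ccc(/C=C/c2cc(=O)cco2)cc1OC` share another, and the difference between the two cores is not broken down here. In an ADME assay on HaCaT cells (Homo sapiens) for inhibition, read by sulforhodamine B assay, with a stated time of 48 h (a lower number here means a stronger inhibitor of growth, a higher number a weaker inhibitor of growth), compound 1 gives 127 uM, and compound 2 gives 145 uM. For the measured compounds named here, the one step with a precedent is a 1.1-fold higher number from compound 1 to compound 2 (0.06 log units; within the scatter), which corresponds to methoxy in place of hydrogen on an aromatic carbon. In this assay compound 3 gives 710 uM, the highest of the three numbers, beyond the scatter from both compound 1 and compound 2.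

Compound 4 carries the same kind of change relative to compound 3: methoxy in place of hydrogen on an aromatic carbon. The two places are not the same: in compound 2 the entering group is para to a group of 9 heavy atoms, whereas in compound 4 it is ortho to a methoxy group and meta to a group of 9 heavy atoms, on a core that differs. Going by the values given here, the expectation rests on the single precedent a 1.1-fold higher number from compound 1 to compound 2 (0.06 log units; within the scatter), which stayed within the scatter, so the expected step for compound 4 is a 1.0-fold higher number from compound 3 to compound 4 (0.01 log units; within the scatter). For compound 4 the expected value in this assay is 720 uM, with a range from 360 uM to 1450 uM. Because compound 3 already stands at 710 uM, the expected range for compound 4 is set to reach further upward than downward.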

Compound 4, concentration for growth inhibition (reported as GI): 690 uM
For compound 4 the middle estimate is 1.0-fold (0.02 log units) above the measured one; low and high end bracket the measured number.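

In this assay the new step is a 1.0-fold lower number from compound 3 to compound 4 (0.01 log units; within the scatter), so methoxy in place of hydrogen on an aromatic carbon gives no change beyond the scatter on this core, as on the core of compound 1. Set side by side, the two steps do not differ: the same change on two cores in this assay, a 1.1-fold higher number (0.06 log units; within the scatter) from compound 1 to compound 2 and a 1.0-fold lower number (0.01 log units; within the scatter) from compound 3 to compound 4, 1.2-fold (0.07 log units) apart, within the scatter of two such steps. For the compounds shown here, this shows that in these two pairs the change carried from one core to the other without a difference beyond the scatter, but it does not show that the same would hold on other cores or at other places, as it rests on only two pairs, and the entering methoxy group stands at a different place in each.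

From the compounds shown here alone, whether an amine or a carboxylic acid on the same aromatic ring would move the number beyond the scatter on either core remains open. Also open, going by these compounds, is how a longer chain in place of methoxy would behave on the two cores.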